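Amino in Place of Fluoro: Expected Shift in Solubility

A few compounds are considered here, and "the series" means these few. Any claim that something is new, unique, unknown or untested is made for them only; others in the source may bear on it.

Of the compounds shown here, three have been measured in a physicochemical assay for solubility, read by HPLC, using the shake flask method, measured as kinetic solubility, with a stated time of 2 h, at pH 7.4; a lower number here means a less soluble compound, a higher number a more soluble compound. Compound 1 `Cc1cc(NCc2nccs2)n2nc(C)c(-c3ccccc3)c2n1` gives 108000 nM. Compound 2 `Cc1cc(NCc2ccccn2)n2ncc(-c3cccc(F)c3)c2n1` gives 5000 nM, and compound 3 `Cc1cc(NCc2ccccn2)n2ncc(-c3ccc(C(=O)Nc4ccccc4)cc3)c2n1` gives 5000 nM. Compound 2 and compound 3 stand level at the digits shown, within the usual scatter of this assay, and together they hold the two lowest numbers of the three; the number for compound 1 lies higher, beyond the scatter. No two of these measured compounds differ in only one place, so no single structural step can be read from them directly.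

Compound 4 `Cc1cc(NCc2ccccn2)n2ncc(-c3cccc(N)c3)c2n1` has not yet been measured. It differs from compound 2 in one place: amino in place of fluoro on an aromatic carbon. Within the data shown here, with no comparable step among the measured compounds, the direction and size of the change in this assay must be estimated rather than read off. The expectation is a moderate rise in solubility, a 3.0-fold higher number from compound 2 to compound 4 (0.48 log units; beyond the scatter), a step beyond the scatter yet still modest. Compound 4 is therefore expected to give about 15000 nM, within a range from 5000 nM to 50000 nM.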

Compound 4, solubility: 160000 nM
Beside the measured number, compound 4's estimate is 11-fold (1.03 log units) below it; measured number outside the range, above it.
By their numbers in this assay, from the lowest: compounds 2 and 3 (each within the scatter of the next); then compounds 1 and 4 (each within the scatter of the next).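

In this assay, putting amino in place of fluoro on an aromatic carbon, meta to a large group, gives a 32-fold higher number from compound 2 to compound 4 (1.51 log units; beyond the scatter), a large step. Among these compounds, this is the first change in the set that can be read in one place, and it shows that the number at this position can move far beyond the scatter with the rest of the molecule held constant. Nothing available explains why the step is this large.

From the compounds shown here alone, it remains open whether a methylamino group, a hydroxyl group or a carboxylic acid in the same place would move the number as far as amino does, or whether the step depends on amino specifically. Going by these compounds, it is also open whether the same exchange of fluoro for amino would give a step of similar size on a different core.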